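Trading a sulfonyl for a sulfanyl on a shared enone core

The source may hold more compounds than are shown below. What is called first, only, known or untested is meant among the compounds shown, and "the series" means these compounds.

Of the compounds shown here, three have been tested so far in a functional assay on DU-145 cells (Homo sapiens) for inhibition, read by trypan blue exclusion, with a stated time of 96 h; on this read-out lower numbers stand for stronger inhibition of growth and higher numbers for weaker inhibition of growth. Compound 1 `O=C(/C(=C\c1ccc(O)c([N+](=O)[O-])c1)S(=O)(=O)Cc1ccc(Br)cc1)c1c(F)c(F)c(F)c(F)c1F` gives 50000 nM, level with compound 3 `Cc1ccsc1/C=C(/SCc1ccc(Cl)c(Cl)c1)C(=O)c1ccc(Cl)cc1`, which gives 50000 nM; together these are the highest numbers of the three. The lowest belongs to compound 2 `COc1ccc(/C=C(/SCc2ccc(Cl)cc2)C(=O)c2ccc(Cl)cc2)cc1`, which gives 10000 nM in this assay , a gap from compound 1 that lies beyond the scatter.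

Compound 4 `O=C(/C(=C\c1ccc(O)c([N+](=O)[O-])c1)SCc1ccc(Br)cc1)c1c(F)c(F)c(F)c(F)c1F` differs from compound 1 in one place: (4-bromobenzyl)sulfanyl in place of (4-bromobenzyl)sulfonyl on a double-bonded chain carbon bound to a carbonyl carbon and a double-bonded chain carbon. For the measured compounds named here, no measured pair shows this exact change, so the size of the step is uncertain. Compounds 2 and 3 both carry a sulfanyl group, yet their numbers in this assay fall on either side of what such a change might bring, so a small improvement or no change beyond the scatter is the most that can be expected.

The expected step of a 1.7-fold lower number from compound 1 to compound 4 (0.22 log units; within the scatter) is modest. Compound 4 is estimated at 30000 nM, with a likely range from 8000 nM to 100000 nM.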

Compound 4, concentration for 50% growth inhibition: 10000 nM
Beside the measured number, compound 4's estimate is 3.0-fold (0.48 log units) above it; measured number inside the range.
By their numbers in this assay, from the lowest: compounds 2 and 4 (each within the scatter of the next); then compounds 1 and 3 (each within the scatter of the next).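

In this assay, for the compounds shown here, putting (4-bromobenzyl)sulfanyl in place of (4-bromobenzyl)sulfonyl gives a 5.0-fold lower number from compound 1 to compound 4 (0.70 log units; beyond the scatter), the first change in this set that can be read in one place alone. It shows that this double-bonded chain carbon is sensitive to what its sulfur carries: with the rest of compound 1 unchanged, removing the two oxygen atoms on sulfur moves the number beyond the scatter. Nothing available explains why the number moves.

As far as these compounds go, this is a single pair, so it sets no general rule for other cores, and what a sulfonyl would do on the cores of compounds 2 and 3 remains open. Also open, from the compounds shown here alone, is whether a sulfinyl group, an ether oxygen or a methylene in place of the sulfur would keep this step, enlarge it or lose it.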